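Trimming the Chain of Compound 2

A few compounds are considered here, and "the series" means these few. Any claim that something is new, unique, unknown or untested is made for them only; others in the source may bear on it.

Compound 2 (`CCCCCCCCCNC[C@@H]1OC[C@H](N)[C@H]1O`) gives > 128000 nM in a functional assay on A549 cells (Homo sapiens) for antiproliferative activity, read by MTT assay, with a stated time of 72 h (on this read-out lower numbers stand for stronger inhibition and higher numbers for weaker inhibition), which is a limit of the assay and not a number. Compound 4 (`CCCCCCCNC[C@@H]1OC[C@H](N)[C@H]1O`) differs from it by hydrogen in place of ethyl on a saturated chain carbon, seven bonds along the chain from an amine nitrogen. Compound 4 carries the same chain as compound 1 (`CCCCCCCNC[C@@H]1OC[C@H](N)[C@@H]1O`), which gives > 128000 nM, also a limit of the assay. Compound 3 (`CCCCCCCCCCCCNC[C@@H]1OC[C@H](N)[C@@H]1O`), with a longer chain, gives 5870 nM in this assay. Going by the values given here, the one measured step that bears on the change is an at least 21-fold lower number from compound 1 to compound 3 (1.33 log units; beyond the scatter), which lengthens the chain and so runs opposite to this shortening. Its size is only a bound, set by the limit of > 128000 nM in this assay, at which 2 of the 3 values shown sit. Compounds 1 and 3 also share a stereochemistry that compound 2 and compound 4 do not, so the transfer is imperfect. No gain in inhibition is expected, and the expected change is a step that the limit leaves unreadable from compound 2 to compound 4. For compound 4 the estimated value is 180000 nM, with an expected range from 100000 nM to 400000 nM.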

Compound 4, half-maximal inhibitory concentration: > 128000 nM
Compound 4 ended at the assay's limit; the forecaster's own chance of this, stated with the estimate: 92%; the middle value does not contradict the limit.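

Compound 4 gives only a limit of the assay in this assay and not a number, so the steps to it from compound 2 and from compound 1 cannot be read: the limit of > 128000 nM in this assay, at which 3 of the 4 values shown sit. The compounds shown leave open whether the ethyl separating compound 2 from compound 4, or the configuration separating compound 1 from compound 4, changes the activity at all.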